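Swapping chloro for methyl on the thiourea aryl ring

The compounds below may be only part of what the source reports. "The series", "measured", "known", "first", "only" and "open" are said of these compounds alone.

In a functional assay on NCI-H460 cells (Homo sapiens) for inhibition, read by CCK-8 assay, with a stated time of 48 h (on this read-out higher numbers stand for weaker inhibition and lower numbers for stronger inhibition), the measured compounds give:
compound 1 `Cc1ccc(NC(=S)NC(=O)c2cn(-c3ccccc3)nc2-c2ccc(F)cc2)cc1` gives 2980 nM
compound 2 `COc1ccc(NC(=S)NC(=O)c2cn(-c3ccccc3)nc2-c2ccc(OC)cc2)cc1` gives 2570 nM
compound 3 `COc1ccc(-c2nn(-c3ccccc3)cc2C(=O)NC(=S)Nc2ccc(Cl)cc2)cc1` gives 3010 nM

Compound 3 holds the highest of the three numbers, yet all three lie within the scatter of one another. For the measured compounds named here, the one step that changes a single place, a 1.2-fold higher number from compound 2 to compound 3 (0.07 log units; within the scatter), stays within the scatter. Compound 4 `COc1ccc(-c2nn(-c3ccccc3)cc2C(=O)NC(=S)Nc2ccc(C)cc2)cc1` differs from compound 3 by methyl in place of chloro on an aromatic carbon. The step from compound 2 to compound 3 is the only one that bears on this exchange, and it was within the scatter; compound 1, which carries the methyl group, also sits within the scatter of compound 3. Compound 4 is therefore expected to show a 1.0-fold lower number from compound 3 to compound 4 (0.00 log units; within the scatter), no step beyond the scatter, with an estimate of 3000 nM and a range from 1500 nM to 6000 nM.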

Compound 4, half-maximal inhibitory concentration: 2880 nM
Beside the measured number, compound 4's estimate is 1.0-fold (0.02 log units) above it; the measured number falls inside the stated range.
By their numbers in this assay, from the lowest: compounds 2, 4, 1 and 3 (each within the scatter of the next).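

In this assay, methyl in place of chloro on the aryl ring of the thiourea gives a 1.0-fold lower number from compound 3 to compound 4 (0.02 log units; within the scatter) and so leaves the number unmoved at this position. Methyl against methoxy at the same place gives a 1.1-fold higher number from compound 2 to compound 4 (0.05 log units; within the scatter) and thus adds a third group to the two already compared there, with no separation among them. Methoxy in place of fluoro elsewhere on the shared core gives a 1.0-fold lower number from compound 1 to compound 4 (0.01 log units; within the scatter) and shows that this second position also stays within the scatter for this pair.

Going by these compounds, whether an amine or a carboxylic acid at the thiourea aryl position would shift the number beyond the scatter remains open. Nothing available accounts for this flat result.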